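Pyrazoline Acyl Ureas and Thioureas in a Rat Edema Model

This account rests on a few compounds, and the source may have more. Where it says the series, first, only, none or still open, it means among the compounds named here.

The study compares three measured pyrazolines and one unmeasured analogue. Compound 3 `COc1ccc(C2=NN(C(=O)NS(=O)(=O)c3ccc(C)cc3)CC2C)c(OC)c1` carries a methyl on a saturated ring carbon and in a functional assay on the whole organism (strain albino) for inhibition, with Rattus norvegicus as the target, read by paw edema, with stated times of 30 min and 3 h, at a dose of 25 mg/kg by the intraperitoneal route (on this read-out lower numbers stand for less inhibition and higher numbers for more inhibition at the one dose given (going by the name of the read-out)), compound 3 gives 25.2%. Compound 1 `COc1ccc(C2=NN(C(=O)NS(=O)(=O)c3ccc(C)cc3)CC2c2ccccc2)c(OC)c1` differs from it by phenyl in place of methyl on a saturated ring carbon, and in this assay compound 1 gives 4.83%; the step of a number 20.4 percentage points lower from compound 3 to compound 1 (beyond the scatter). Compound 2 `COc1ccc(C2=NN(C(=S)NC(=O)c3ccc(Cl)cc3)CC2C)c(OC)c1` has a different side chain; the difference between the core of compound 2 and the core of compound 3 is not broken down here. In this assay compound 2 gives 1.94%, and the values of compound 2 and compound 1 lie within the scatter of each other.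

Compound 4 `COc1ccc(C2=NN(C(=S)NC(=O)c3ccc(Cl)cc3)CC2c2ccccc2)c(OC)c1` is not yet measured. It relates to compound 2 by phenyl in place of methyl on a saturated ring carbon, the same change that links compound 3 to compound 1. Because compound 2 already gives 1.94%, there is little room for a drop of the earlier size, so the step from compound 2 to compound 4 is expected to be a number 0.9 percentage points lower from compound 2 to compound 4 (within the scatter). Compound 4 is expected to give about 1% in this assay, between 0% and 8%.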

Compound 4, a percentage reported as inhibition, in the whole organism at one dose (the size of the read-out at that dose, not a potency): 1.43%
Compound 4: the middle estimate sits 0.4 percentage points below what was measured; the range from low to high includes it.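

In this assay, phenyl in place of methyl on a saturated ring carbon gives a number 0.5 percentage points lower from compound 2 to compound 4 (within the scatter), so the change does not carry over at one size from one core to the other: the same change on two cores in this assay, a number 20.4 percentage points lower (beyond the scatter) from compound 3 to compound 1 and a number 0.5 percentage points lower (within the scatter) from compound 2 to compound 4, 19.9 percentage points apart, beyond the scatter of two such steps

This shows that, in these two pairs, the size of the step depends on the core it is made on, and that a clear loss on one core cannot be assumed on the other. It does not show what sets that size: compound 2 already starts at 1.94%, and with a single pair on each core the data cannot separate an effect of the side chain from the small part of the read-out left to lose.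

The compounds shown leave open what an ethyl group, a longer chain or an amine would give on that saturated ring carbon. Among the compounds shown here, they also leave open how the two side chains compare when only one part of them changes, such as the sulfur of the thiocarbonyl exchanged for the oxygen of a carbonyl.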